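This account rests on a few compounds, and the source may have more. Where it says the series, first, only, none or still open, it means among the compounds named here.

The study concerns cytotoxicity alone. Compound 1 has the structure `COc1ccc(-n2c(=O)n(Cc3cc4cc(Cl)ccc4n3CCCC#N)c3cnccc32)c(F)c1`. In an ADME assay on HeLa cells (Homo sapiens) for cytotoxicity, read by ATP content, with a stated time of 3 days (on this read-out lower numbers stand for higher toxicity in this test and higher numbers for lower toxicity in this test), compound 1 gives only a limit, > 50000 nM. Compound 2, `O=c1n(Cc2cc3cnccc3n2CCCC(F)(F)F)c2cnccc2n1C1CC1`, shares the core of compound 1 and carries a cyclopropyl group and a trifluoromethyl-bearing chain instead. In this assay compound 2 likewise reaches only a limit, > 50000 nM. Compound 3, `O=c1n(Cc2cc3ccc(Cl)cc3n2CCCCO)c2cnccc2n1C1CC1`, also stops at a limit in this assay, > 50000 nM. Within the data shown here, all that is known is therefore (the limit of > 50000 nM in this assay, at which 3 of the 3 values shown sit), and no step between two measured compounds with a number on each side exists. Compound 1 stands exactly where the other two stand, at the limit of this assay, with no number to set it apart.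

Compound 4, `COc1ccc(-n2c(=O)n(Cc3cc4cc(Cl)ccc4n3CCCC#N)c3cnccc32)c(C)c1`, has not yet been tested in this assay. Among the measured compounds shown here, its single difference from compound 1 is methyl in place of fluoro on an aromatic carbon, a change of one heavy atom ortho to a large group and meta to a methoxy group. For the measured compounds named here, with every measured compound at the limit and no step to go by, the step expected is a number no higher from compound 1 to compound 4 (the limit leaves the size open), none beyond the scatter. Compound 4 is therefore expected to give roughly 50000 nM in this assay, with a range from 20000 nM to 100000 nM, most probably once more reported only as a limit.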

Compound 4, half-maximal cytotoxic concentration: > 50000 nM
Compound 4: no number, only a limit; the forecaster's own chance of this, stated with the estimate: 80%; the middle value sits exactly at the limit.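

Among these compounds, compound 4 gives only a limit, as compound 1 does, so no step between compound 1 and compound 4 can be read in this assay. The compounds shown leave open what number any of them would give, and so whether methyl in place of fluoro changes the read-out at all: the limit of > 50000 nM in this assay, at which 4 of the 4 values shown sit.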